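The source may hold more compounds than are shown below. What is called first, only, known or untested is meant among the compounds shown, and "the series" means these compounds.

The study concerns three compounds already measured for cytotoxicity and a fourth that still awaits measurement. Compound 1 `CNC(=O)c1ccc(NCc2cncn2Cc2ccc(-c3ccccc3)cc2N)cc1-c1ccccc1` was tested in a toxicity assay on NIH3T3 cells (Mus musculus) for cytotoxicity, read by resazurin assay (a higher number here means that more compound is needed for the effect, a lower number that less compound is needed), and is reported only as a limit of the assay, > 1000 nM. Compound 2 `Cc1cccc(-c2cccc(NCc3cncn3Cc3ccccc3)c2)c1C` likewise gives only a limit in this assay, > 1000 nM. For the measured compounds named here, compound 3 `COC(=O)c1ccc(NCc2cncn2Cc2ccccc2N)cc1-c1ccccc1` is the one member of the set with a true number: in this assay compound 3 gives 25000 nM. Among the three values shown, compound 3 therefore stands alone as the only figure, while the other two sit at the limit of > 1000 nM in this assay, at which 2 of the 3 values shown sit, and no ordering between the three can be drawn from that.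

Compound 4 `COC(=O)c1ccc(NCc2cncn2Cc2ccc(Cl)cc2)cc1-c1ccccc1` has not yet been measured in this assay. It differs from compound 3 in one place: 4-chlorophenyl in place of 2-aminophenyl on a saturated chain carbon bound to an aromatic nitrogen. Going by the values given here, no step between measured compounds is available to show how such a change moves the read-out, so the expectation rests on compound 3 alone. The step of a 1.3-fold lower number from compound 3 to compound 4 (0.10 log units; within the scatter) is expected to stay within the usual scatter, with no direction favoured. The half-maximal effective concentration of compound 4 in this assay is estimated at 20000 nM, with a range from 7000 nM to 50000 nM.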

Compound 4, half-maximal effective concentration: 25000 nM
For compound 4 the middle estimate is 1.3-fold (0.10 log units) below the measured one; the measured number falls inside the stated range.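

In this assay, 4-chlorophenyl in place of 2-aminophenyl on a saturated chain carbon bound to an aromatic nitrogen gives no change at the digits printed from compound 3 to compound 4 (within the scatter). For the compounds shown here, this is the first step in the set that can be read, whereas the earlier compounds offered a single number with nothing to set it against. The group that leaves counts 1 hydrogen-bond donor and 1 hydrogen-bond acceptor and the group that enters counts 0 of each, yet the read-out of this one pair stays within the scatter, and the finding extends no further than compound 3 and compound 4.

No other step in the set can be read, because the remaining values are limits of the assay and not numbers: the limit of > 1000 nM in this assay, at which 2 of the 4 values shown sit.

Still open, as far as these compounds go, is how the read-out in this assay would respond at this position to a carboxylic acid, an aliphatic amine or a longer chain in place of the 2-aminobenzyl or 4-chlorobenzyl group, and whether the exchange from 2-aminobenzyl to 4-chlorobenzyl would read the same on any core other than that of compound 3.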